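A few compounds are considered here, and "the series" means these few. Any claim that something is new, unique, unknown or untested is made for them only; others in the source may bear on it.

Measured so far in a functional assay on the whole organism (strain albino) for inhibition, with Rattus norvegicus as the target, read by paw edema, with stated times of 1 h and 0.5 h, at a dose of 100 mg/kg by the oral route; a higher number here means more inhibition at the dose given (going by the name of the read-out), a lower number less inhibition:
compound 1 `N#Cc1c(Cl)nc(SCC(=O)Nn2c(COc3ccc(Cl)cc3Cl)nc3ccccc3c2=O)nc1-c1ccc(O)cc1` gives 67.3%
compound 2 `N#Cc1c(Nc2ccccc2)nc(SCC(=O)Nn2c(COc3ccc(Cl)cc3Cl)nc3ccccc3c2=O)nc1-c1ccc(O)cc1` gives 90.4%

For the measured compounds named here, compound 2 stands at the top of the two numbers measured in this assay; the only step, a number 23.1 percentage points higher from compound 1 to compound 2 (beyond the scatter), separates it from compound 1 by more than the scatter, and that step is the one in which anilino replaces chloro on an aromatic carbon of the shared core.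

Compound 3 `N#Cc1c(Nc2ccc(O)cc2)nc(SCC(=O)Nn2c(COc3ccc(Cl)cc3Cl)nc3ccccc3c2=O)nc1-c1ccc(O)cc1` is the next compound to be measured. Its change from compound 2 is hydroxy in place of hydrogen on an aromatic carbon, that is, anilino becomes (4-hydroxyphenyl)amino.

Going by the values given here, none of the measured steps bears on this change: the one step on hand alters the group attached to the core, not a substituent on the anilino ring, so it says nothing about adding a hydroxy there. With no guide in the data, the expectation for a number 3.4 percentage points lower from compound 2 to compound 3 (within the scatter) is a step that stays within the scatter, in no particular direction, with the high value of compound 2 leaving more room downward than upward. Compound 3 is therefore estimated at 87%, with a range from 74% to 97%.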

Compound 3, a percentage reported as inhibition, in the whole organism at one dose (the size of the read-out at that dose, not a potency): 80.8%
For compound 3 the middle estimate is 6.2 percentage points above the measured one; measured number inside the range.
By their numbers in this assay, from the lowest: compound 1; then compounds 3 and 2 (each within the scatter of the next).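

In this assay, for the compounds shown here, the step of a number 9.6 percentage points lower from compound 2 to compound 3 (within the scatter) shows that the anilino ring of compound 2 can carry a hydroxy para to a large group without a change that can be told from the scatter, so this is the first reading of a substituent on that ring rather than of the group attached to the core. The step of a number 13.5 percentage points higher from compound 1 to compound 3 (beyond the scatter) adds that (4-hydroxyphenyl)amino, like anilino, stands apart from chloro on the shared core by more than the scatter, so the difference from compound 1 holds for two groups at that carbon and not for anilino alone. Nothing on hand accounts for these readings, and no measurement of any property of the hydroxy group bears on them.

The compounds shown leave open whether a methoxy, an amine or a carboxylic acid at the same carbon of the anilino ring would read like hydroxy, and whether hydroxy would do so on another carbon of that ring. They also leave open whether an aliphatic amine such as morpholine, in place of chloro on the core, would stand apart from compound 1 as the two aromatic amines do.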